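This account rests on a few compounds, and the source may have more. Where it says the series, first, only, none or still open, it means among the compounds named here.

Compound 1 `CCOC(=O)/C(O)=C/C(=O)c1cn(Cc2ccc(F)c(F)c2)c2cccc(OC)c12` gives 125000 nM in an ADME assay on MT4 cells (Homo sapiens) for cytotoxicity, read by MTT assay; a lower number here means that less compound is tolerated, a higher number that more compound is tolerated; compound 2 `COc1cccc2c1c(C(=O)/C=C(\O)C(=O)O)cn2Cc1ccc(F)cc1` gives 41100 nM; compound 3 `COc1cccc2c1c(C(=O)/C=C(\O)C(=O)O)cn2Cc1cc(F)c(F)c(F)c1` gives 23300 nM.

Among these three, compound 1 stands highest in this assay: compound 2 lies a step below it, and compound 3 lies further below, both gaps beyond the scatter. For the measured compounds named here, compound 1 carries an ethyl ester where compound 2 and compound 3 carry a free acid, so no single-point step connects it to either of them.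

Compound 4 `CCOC(=O)/C(O)=C/C(=O)c1cn(Cc2ccc(F)c(F)c2F)c2cccc(OC)c12` differs from compound 1 by fluoro in place of hydrogen on an aromatic carbon. Going by the values given here, the one measured step that touches the same part of the molecule is a 1.8-fold lower number from compound 2 to compound 3 (0.25 log units; within the scatter), where more fluorine on the benzyl ring changed the number only within the scatter. On that basis, the added fluoro in compound 4 is expected to leave this assay little changed, with the step of a 1.3-fold lower number from compound 1 to compound 4 (0.10 log units; within the scatter) expected to stay within the scatter, if anything slightly downward. Compound 4 is therefore estimated at 100000 nM, with a range from 50000 nM to 200000 nM.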

Compound 4, half-maximal cytotoxic concentration: 42700 nM
Beside the measured number, compound 4's estimate is 2.3-fold (0.37 log units) above it, outside the stated range (below it).
By their numbers in this assay, from the lowest: compounds 3, 2 and 4 (each within the scatter of the next); then compound 1.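

Placing a fluoro on this aromatic carbon, ortho to a fluoro group and ortho to a large group, turns the 3,4-difluorobenzyl group of compound 1 into the 2,3,4-trifluorobenzyl group of compound 4 and changes this assay by more than the scatter: a 2.9-fold lower number from compound 1 to compound 4 (0.47 log units; beyond the scatter). The earlier change of fluorine substitution on the benzyl ring, a 1.8-fold lower number from compound 2 to compound 3 (0.25 log units; within the scatter), stayed within the scatter, but it was a different change, made on a free acid rather than an ethyl ester. A single added fluoro on the benzyl ring can therefore shift this number measurably in the ethyl ester.

As far as these compounds go, whether a chloro or methyl group at this position would give a similar step remains open, as does the effect of this same fluoro on the free acid. The compounds shown offer no measurement that would explain the step.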